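A few compounds are considered here, and "the series" means these few. Any claim that something is new, unique, unknown or untested is made for them only; others in the source may bear on it.

Of the compounds shown here, two have been measured so far in a functional assay on MCF7 cells (Homo sapiens) for cytotoxicity, read by MTT assay, with a stated time of 72 h; a lower number here means that less compound is tolerated, a higher number that more compound is tolerated. Compound 1 `C=CCOC(=O)Nc1ccc([Se]C#N)cc1` gives 71200 nM in this assay. Compound 2 `CCCCOC(=O)Nc1ccc([Se][Se]c2ccc(NC(=O)OCCCC)cc2)cc1` gives 75200 nM in this assay. Compound 1 stands at the lowest of the two numbers, and compound 2 lies within the scatter of it, so the two compounds cannot be told apart on these data. Compound 3 `N#C[Se]c1ccc(NC(=O)Oc2ccccc2)cc1` has not been measured. Its difference from compound 1 is phenyl in place of allyl on an oxygen next to a carbonyl group. Among the compounds with values here, no measured pair shows this change, so there is no step to lean on. The expected step from compound 1 to compound 3 in this assay is a 1.2-fold lower number from compound 1 to compound 3 (0.07 log units; within the scatter), which is not beyond the scatter. Compound 3 is therefore estimated at 60000 nM in this assay, with a range from 25000 nM to 150000 nM.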

Compound 3, concentration lethal to 50% of the cells: 67800 nM
Compound 3: the middle estimate sits 1.1-fold (0.05 log units) below what was measured; measured number inside the range.
By their numbers in this assay, from the lowest: compounds 3, 1 and 2 (each within the scatter of the next).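

Replacing allyl with phenyl on an oxygen next to a carbonyl group gives, in this assay, a 1.1-fold lower number from compound 1 to compound 3 (0.02 log units; within the scatter). Within the data shown here, this is the first direct comparison at this position, and it shows that an open chain with a double bond and an aromatic ring with more heavy atoms cannot be told apart here. No measurement available explains why the two groups read alike.

Going by these compounds, both groups consist of carbon only and carry no charge, so it remains open whether a group of another kind at this oxygen, such as an amine or a carboxylic acid, would move the number beyond the scatter. On these data alone, it is also open how far a change elsewhere in the core of compound 1 would shift this cytotoxicity reading.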